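Working notes on the five-membered ring substituent, compound 3

This account rests on a few compounds, and the source may have more. Where it says the series, first, only, none or still open, it means among the compounds named here.

Measured so far in an in vitro functional assay on cells for agonist activity at Bombesin receptor subtype-3 (Homo sapiens), read by luminescence and calcium flux; on this read-out lower numbers stand for an effect already at smaller amounts and higher numbers for an effect only at larger amounts of compound:
- compound 1 `O=C(O)c1ccccc1-c1ccc(CCc2ncc(CC3CCC3)[nH]2)cc1`: 588 nM
- compound 2 `O=C(O)c1ccccc1-c1ccc(CCc2ncc(-c3ccccc3)[nH]2)cc1`: 4950 nM

Within the data shown here, compound 2 carries the highest number of the two measured compounds; its nearest neighbour is compound 1, which sits a step of an 8.4-fold higher number from compound 1 to compound 2 (0.93 log units; beyond the scatter) away, the only measured step in the set. The next compound to be measured is compound 3 `O=C(O)c1ccccc1-c1ccc(CCc2ncc(CC3CCCCCC3)[nH]2)cc1`, which differs from compound 2 by cycloheptylmethyl in place of phenyl on an aromatic carbon.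

The step from compound 1 to compound 2 bears directly on this change: both involve the same aromatic carbon, and both contrast a cycloalkylmethyl group against phenyl. Putting phenyl in place of cyclobutylmethyl raised the number clearly beyond the scatter, so reversing the direction and installing cycloheptylmethyl is expected to lower the number again. How far a seven-membered ring departs from the four-membered one cannot be judged from the two compounds available, so the expected step is kept somewhat smaller than the measured one and the range is left wide.

For compound 3 the expected step is a 5.5-fold lower number from compound 2 to compound 3 (0.74 log units; beyond the scatter) in this assay. The estimated value for compound 3 is 900 nM, with a range from 250 nM to 3000 nM.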

Compound 3, half-maximal effective concentration: 88 nM
Compound 3: middle estimate off by 10-fold (1.01 log units), on the high side; measured number below the stated range.
By their numbers in this assay, from the lowest: compound 3; then compound 1; then compound 2.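

In this assay, among these compounds, the step of a 56-fold lower number from compound 2 to compound 3 (1.75 log units; beyond the scatter) shows that the choice of group on this aromatic carbon of the five-membered aromatic ring with 2 nitrogen can span a much wider range than the single earlier step revealed. The step of a 6.7-fold lower number from compound 1 to compound 3 (0.82 log units; beyond the scatter) adds something the earlier pair could not show: with the cycloalkylmethyl form kept, ring size alone moves the number beyond the scatter, and here the seven-membered ring gives the lower number. No measurement at hand explains either step.

From the compounds shown here alone, two compounds cannot establish a trend with ring size, so it remains open whether cyclopentylmethyl and cyclohexylmethyl would fall between compound 1 and compound 3, or whether a larger cyclooctylmethyl would lower the number further. The step from phenyl to cycloheptylmethyl also changes both the ring and the presence of a methylene link, so benzyl and directly attached cycloheptyl are the groups that would separate these two contributions.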